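This account rests on a few compounds, and the source may have more. Where it says the series, first, only, none or still open, it means among the compounds named here.

In a functional assay on OCI-Ly3 cells (Homo sapiens) for antiproliferative activity (on this read-out lower numbers stand for an effect already at smaller amounts and higher numbers for an effect only at larger amounts of compound), compound 1 `O=C(Nc1cnc(-n2nccn2)c(Cl)c1)Nc1cnc2cc(Cl)ccc2c1C1CC1` reads > 20000 nM, which is a limit of the assay and not a number. Two related ureas give real numbers: compound 2 `COC(C)c1c(NC(=O)Nc2cnc(-n3nccn3)c(Cl)c2)cnc2ccccc12` gives 620 nM, and compound 3 `COC(C)c1c(NC(=O)Nc2cnc(-n3nccn3)c(Cl)c2)cnc2ccc(F)cc12` gives 270 nM, the lower of the two. Compound 3 is therefore the best-placed starting point on these numbers.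

The next compound, compound 4 `CC(O)c1c(NC(=O)Nc2cnc(-n3nccn3)c(Cl)c2)cnc2ccc(F)cc12`, changes one small detail of compound 3: hydrogen replaces methyl on an oxygen on a saturated carbon, turning 1-methoxyethyl into 1-hydroxyethyl (hydrogen in place of methyl on an oxygen on a saturated carbon).

For the measured compounds named here, no measured step makes this same change. The closest guide to size is a 2.3-fold lower number from compound 2 to compound 3 (0.36 log units; beyond the scatter), but that step places fluoro in place of hydrogen on an aromatic carbon, so it bears only loosely on this one. It offers no direction for the new change, and the direction here is a cautious guess. Going by these compounds, a modest shift toward a higher number is expected, giving an estimated 1.9-fold higher number from compound 3 to compound 4 (0.27 log units; within the scatter), though a wide range remains open. For compound 4 the expected value is 500 nM, with an estimated range from 120 nM to 2500 nM.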

Compound 4, half-maximal effective concentration: 560 nM
Compound 4: the middle estimate sits 1.1-fold (0.05 log units) below what was measured; the measured number falls inside the stated range.
By their numbers in this assay, from the lowest: compound 3; then compounds 4 and 2 (each within the scatter of the next). At a limit, above all of these: compound 1.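

Within this assay, this is the first measured change on the oxygen of the side chain, as opposed to the aromatic carbon that carried the earlier fluoro step. Swapping the methyl for hydrogen on that oxygen gives a 2.1-fold higher number from compound 3 to compound 4 (0.32 log units; beyond the scatter), so the methyl cannot be changed to hydrogen here without the number moving, although the move is modest and compound 4 still reads as a real number and not as a limit. Nothing measured here bears on why the number moves in this direction.

Still open, going by these compounds, is how an amine in place of the hydroxy group, or a longer chain on the oxygen such as ethoxy, would read. Also open, on these data alone, is whether the same change would give a step of similar size without the fluoro, as in compound 2.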